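The source may report more compounds than this note shows. Statements on the series, on what has been measured and on what is new or still open speak of the compounds shown alone.

Measured compounds:
- compound 1, `O=C(CSc1nc(Nc2ccccc2)c2ccccc2n1)Nc1ccccc1F`; in a functional assay on MDA-MB-231 cells (Homo sapiens) for inhibition, read by MTT assay, with a stated time of 72 h (on this read-out lower numbers stand for stronger inhibition and higher numbers for weaker inhibition), compound 1 gives > 50000 nM, which is a limit of the assay and not a number.
- compound 2, `O=C(CSc1nc(Nc2ccccc2)c2ccccc2n1)Nc1cccc(F)c1`; in this assay compound 2 gives > 50000 nM, likewise a limit.
- compound 3, `CCc1cccc(NC(=O)CSc2nc(Nc3ccccc3)c3ccccc3n2)c1`; in this assay compound 3 gives 12400 nM.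

Compound 1 thus stands at the limit of > 50000 nM in this assay, at which 2 of the 3 values shown sit, with only compound 3 giving a number. Compound 4, `O=C(CSc1nc(Nc2ccccc2)c2ccccc2n1)Nc1ccc(F)c(Cl)c1`, differs from compound 1 by 3-chloro-4-fluorophenyl in place of 2-fluorophenyl on an amide-type nitrogen. Among the compounds with values here, the steps that bear on this change are a step that the two limits leave unreadable from compound 1 to compound 2, an at least 4.0-fold lower number from compound 1 to compound 3 (0.60 log units; beyond the scatter) and an at least 4.0-fold lower number from compound 2 to compound 3 (0.60 log units; beyond the scatter). Both fluorophenyl amides sit at the limit; only the 3-ethylphenyl amide, compound 3, reads as a number. Compound 4 keeps a fluoro and adds a chloro, a combination not yet tested, so a modest lowering from the limit is possible but not assured. Compound 4 is therefore estimated at 30000 nM, in the range 8000 nM to 100000 nM. This expected outcome corresponds to an at least 1.6-fold lower number from compound 1 to compound 4 (0.22 log units; that floor lies within the scatter).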

Compound 4, half-maximal inhibitory concentration: 21600 nM
Estimate against measurement, compound 4: 1.4-fold (0.14 log units) above, within the range that was stated.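

In this assay, a fluorine-bearing phenyl on the amide-type nitrogen can read as a number, with an at least 2.3-fold lower number from compound 1 to compound 4 (0.36 log units; beyond the scatter) and an at least 2.3-fold lower number from compound 2 to compound 4 (0.36 log units; beyond the scatter). The 3-chloro-4-fluorophenyl and 3-ethylphenyl groups cannot be told apart here, with a 1.7-fold higher number from compound 3 to compound 4 (0.24 log units; within the scatter). The two monofluorophenyl amides, compound 1 and compound 2, remain at a limit of the assay and not a number, and the step between them cannot be read: the limit of > 50000 nM in this assay, at which 2 of the 4 values shown sit.

Going by these compounds, it remains open whether 3-chlorophenyl alone would give a number at this position. Also open, on these data alone, is how an amine or a carboxylic acid on this phenyl would read.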